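Swapping a cyclohexyl for an octyl chain on sulfur

A few compounds are considered here, and "the series" means these few. Any claim that something is new, unique, unknown or untested is made for them only; others in the source may bear on it.

Measured compounds:
Compound 1, `CC(C)c1cccc(C(C)C)c1OC(=O)NC(=O)OCc1ccccc1`: 77 nM
Compound 2, `CC(C)c1cccc(C(C)C)c1OC(=O)NC(=O)SCCCc1ccccc1`: 69 nM
Compound 3, `CC(C)c1cccc(C(C)C)c1OC(=O)NC(=O)SC1CCCCC1`: 97 nM

All three compounds share one core and differ only in the group attached to the outer carbonyl carbon. In an assay on microsomes from intestine for inhibition of acyl-CoA:cholesterol acyltransferase (Oryctolagus cuniculus) (a higher number here means a weaker inhibitor, a lower number a stronger inhibitor), compound 3 gives the highest of the three numbers, but its nearest neighbour, compound 1, lies only a 1.3-fold higher number from compound 1 to compound 3 (0.10 log units; within the scatter) away, and compound 2 only a 1.4-fold higher number from compound 2 to compound 3 (0.15 log units; within the scatter) away; both gaps fall within the scatter of repeated measurements, so the three compounds cannot be told apart on these data.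

Compound 4, `CCCCCCCCSC(=O)NC(=O)Oc1c(C(C)C)cccc1C(C)C`, has not yet been measured. It differs from compound 3 in one place: octyl in place of cyclohexyl on a sulfur. Within the data shown here, the step that bears most directly on this change is the one from compound 2 to compound 3, which also replaced the group on the sulfur and moved the number only within the scatter. The step from compound 1 to compound 3 changed a neighbouring part and was likewise within the scatter. Because a 1.4-fold higher number from compound 2 to compound 3 (0.15 log units; within the scatter) shows an open chain and a ring on the sulfur giving much the same number, compound 4 is expected to change this assay by a 1.2-fold lower number from compound 3 to compound 4 (0.08 log units; within the scatter) at most, with no direction favoured. Compound 4 is therefore estimated at 80 nM, within a range from 35 nM to 200 nM.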

Compound 4, half-maximal inhibitory concentration: 160 nM
Beside the measured number, compound 4's estimate is 2.0-fold (0.30 log units) below it; low and high end bracket the measured number.
By their numbers in this assay, from the lowest: compounds 2, 1, 3 and 4 (each within the scatter of the next, the first and the last beyond it).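

In this assay, octyl in place of cyclohexyl on the sulfur gives a 1.6-fold higher number from compound 3 to compound 4 (0.22 log units; within the scatter) and so, taken alone, cannot be told from repeat-measurement noise. Compound 4 does stand clear of two other compounds, however: pentyl in place of phenyl on a saturated chain carbon, three bonds along the chain from a sulfur, gives a 2.3-fold higher number from compound 2 to compound 4 (0.37 log units; beyond the scatter) even though both compounds carry an open chain on that sulfur, and octylsulfanyl in place of benzyloxy on a carbonyl carbon gives a 2.1-fold higher number from compound 1 to compound 4 (0.32 log units; beyond the scatter) as a second modest step. The group on the outer carbonyl carbon can therefore shift the number past the scatter, which no step among the first three compounds showed, although compound 3 lies within the scatter of all the others and nothing available explains these differences.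

The compounds shown leave open whether a shorter butyl chain or a longer dodecyl chain on the sulfur would continue this small upward shift. They also leave open how an amine or a carboxylic acid at the far end of the chain would read in this assay on this shared core.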